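Aryl swap on a pyrazole acid: compound 2 to compound 3

This account rests on a few compounds, and the source may have more. Where it says the series, first, only, none or still open, it means among the compounds named here.

Compound 1 `Cc1ccccc1-c1c(C)nn(-c2nc(-c3ccc(Cl)c(Cl)c3)c(SC(C)C)s2)c1C(=O)O`: 5500 nM
Compound 2 `COc1cc(Cl)cc(-c2c(C)nn(-c3nc(-c4ccc(Cl)c(Cl)c4)c(SC(C)C)s3)c2C(=O)O)c1`: 760 nM

In a functional assay on BJAB cells (Homo sapiens) for antiproliferative activity, with a stated time of 4 days (on this read-out higher numbers stand for an effect only at larger amounts of compound and lower numbers for an effect already at smaller amounts), compound 2 gives 760 nM, the lowest of the two numbers; compound 1 gives 5500 nM. For the measured compounds named here, the one measured step, a 7.2-fold lower number from compound 1 to compound 2 (0.86 log units; beyond the scatter), changed the same group at the same place, so it bears on compound 3 `CCOc1ncccc1-c1c(C)nn(-c2nc(-c3ccc(Cl)c(Cl)c3)c(SC(C)C)s2)c1C(=O)O`, where the change is 2-ethoxypyridin-3-yl in place of 3-chloro-5-methoxyphenyl on an aromatic carbon. Going by the values given here, that step shows the ring at this position matters, but no measured pair shows this particular exchange. Compound 3 is therefore estimated at 2000 nM, range 600 nM to 7000 nM, an expected step of a 2.6-fold higher number from compound 2 to compound 3 (0.42 log units; beyond the scatter).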

Compound 3, half-maximal effective concentration: 11000 nM
The estimate for compound 3 lay 5.5-fold (0.74 log units) below the measured number; measured number above the stated range.
By their numbers in this assay, from the lowest: compound 2; then compounds 1 and 3 (each within the scatter of the next).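

At this aromatic carbon, the exchange of 3-chloro-5-methoxyphenyl for 2-ethoxypyridin-3-yl in this assay gives a 14-fold higher number from compound 2 to compound 3 (1.16 log units; beyond the scatter) and so loses what compound 2 had gained. Replacing 2-methylphenyl with 2-ethoxypyridin-3-yl gives a 2.0-fold higher number from compound 1 to compound 3 (0.30 log units; within the scatter), so the two groups are not told apart here, and compound 2 alone stands apart among the three. No measurement given here bears on the origin of these steps. A 2-ethoxyphenyl group at this carbon would separate the ring nitrogen from the ethoxy group, which change together here.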